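The compounds below may be only part of what the source reports. "The series", "measured", "known", "first", "only" and "open" are said of these compounds alone.

Measured compounds in the series:
- compound 1 `CN1CCN(C[C@H](O)[C@]23CC[C@H](CC2=O)C3(C)C)CC1`: "not determined" (no result reported)
- compound 2 `CC1(C)[C@@H]2CC[C@@]1([C@@H](O)CN1CCN(c3ccccc3)CC1)C(=O)C2`: "not determined" (no result reported)
- compound 3 `CC1(C)[C@@H]2CC[C@@]1([C@H](O)CN1CCN(c3ccccc3F)CC1)C(=O)C2`: 120000 nM

Among the measured compounds shown here, in an ADME assay on HEK-293T cells (Homo sapiens) for cytotoxicity, read by MTT assay, with a stated time of 72 h (a lower number here means a stronger inhibitor, a higher number a weaker inhibitor), compound 3 gives 120000 nM and is the only entry with a number; compound 1 and compound 2 carry no result, so no measured step exists and compound 3 stands alone as the reference point.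

Compound 4 `CC1(C)[C@@H]2CC[C@@]1([C@@H](O)CN1CCN(c3ccccc3F)CC1)C(=O)C2` differs from compound 3 only in configuration: the two compounds have the same atoms and bonds and differ only in configuration as drawn: 1 of 3 stereo elements differ; a stereocentre at a saturated chain carbon is drawn S in compound 3 and R in compound 4. For the measured compounds named here, with no measured step to draw on, the expectation for this assay is a change that stays within the usual scatter, with no preferred direction.

Compound 4 is therefore expected to give 120000 nM, with a range from 50000 nM to 300000 nM. The estimated step of no change at the digits printed from compound 3 to compound 4 (within the scatter) is meant to lie within the scatter.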

Compound 4, half-maximal inhibitory concentration: 129000 nM
Compound 4: middle estimate off by 1.1-fold (0.03 log units), on the low side, and the stated range covers the measured number.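

In this assay the series now has its first measured step: a 1.1-fold higher number from compound 3 to compound 4 (0.03 log units; within the scatter). For this pair, the stereocentre at a saturated chain carbon can be drawn S or R without the number leaving the scatter. The reading rests on a single changed element: the fact that compounds 3 and 4 differ only in the configuration as drawn

Going by these compounds, the other two stereo elements stay the same in this pair, so their contribution remains open. Also open, on these data alone, is whether the stereocentre would matter as little if the fluorinated phenyl group gave way to a benzyl group or a carboxylic acid.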